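Halogen swap on a fused aryl ring of two isatin-type cores

A few compounds are considered here, and "the series" means these few. Any claim that something is new, unique, unknown or untested is made for them only; others in the source may bear on it.

Compound 1 `O=C1C(=O)N(CN2CCN(c3ccnc4cc(Cl)ccc34)CC2)c2cc(Cl)ccc21` and compound 2 `O=C1C(=O)N(CN2CCN(c3ccnc4cc(Cl)ccc34)CC2)c2cc(Br)ccc21` share one core and differ only at a single halogen. In a functional assay on MCF7 cells (Homo sapiens) for cytotoxicity, read by sulforhodamine B assay, with a stated time of 48 h (on this read-out higher numbers stand for weaker inhibition of growth and lower numbers for stronger inhibition of growth), compound 1 gives 26100 nM, and compound 2 gives 17600 nM. The change between them is bromo in place of chloro on an aromatic carbon and it produced a 1.5-fold lower number from compound 1 to compound 2 (0.17 log units; within the scatter).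

Compound 3 `O=C1C(=O)N(CN2CCN(c3ccnc4cc(C(F)(F)F)ccc34)CC2)c2cccc(Cl)c21` carries a different core; how the two cores differ is not broken down here. In this assay compound 3 gives 16900 nM, which stands within the scatter of both compound 1 and compound 2.

Compound 4 `O=C1C(=O)N(CN2CCN(c3ccnc4cc(C(F)(F)F)ccc34)CC2)c2cccc(Br)c21` is not yet measured. Relative to compound 3 it shows (bromo in place of chloro on an aromatic carbon). This is the same kind of change as that from compound 1 to compound 2, though the surroundings differ: in compound 4 the bromo sits ortho to a fused ring and meta to a fused ring, whereas in compound 2 it sits meta to a fused ring and para to a fused ring.

The account expects a step of about a 1.4-fold lower number from compound 3 to compound 4 (0.15 log units; within the scatter), because the earlier swap gave a 1.5-fold lower number from compound 1 to compound 2 (0.17 log units; within the scatter). For compound 4 the estimated value is 12000 nM, expected to lie between 6000 nM and 30000 nM.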

Compound 4, concentration for 50% growth inhibition: 66800 nM
Compound 4: middle estimate off by 5.6-fold (0.75 log units), on the low side; measured number above the stated range.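

In this assay bromo in place of chloro on an aromatic carbon gave a 4.0-fold higher number from compound 3 to compound 4 (0.60 log units; beyond the scatter) and so did not repeat the small step seen on the core of compound 1. Set side by side, the two steps do not agree: the same change on two cores in this assay, a 1.5-fold lower number (0.17 log units; within the scatter) from compound 1 to compound 2 and a 4.0-fold higher number (0.60 log units; beyond the scatter) from compound 3 to compound 4, 5.9-fold (0.77 log units) apart, beyond the scatter of two such steps. The swap therefore cannot be carried as a fixed step from one core to the other in this series, but these two pairs do not show what lies behind the gap: they differ both in where the halogen sits and in the second substituent, chloro in compound 1 and trifluoromethyl in compound 3, and a single pair per core cannot separate the two.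

The compounds shown leave open whether moving the halogen alone, with the second substituent held fixed, would account for the gap. They also leave open how fluoro, iodo, an amine or a carboxylic acid at the same aromatic carbon would read on either core.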